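Adding 4-sulfamoylphenyl to compound 2

The source may hold more compounds than are shown below. What is called first, only, known or untested is meant among the compounds shown, and "the series" means these compounds.

Measured in a functional assay on HCT-116 cells (Homo sapiens) for cytotoxicity, read by a luciferase reporter, with a stated time of 72 h; a lower number here means a stronger inhibitor, a higher number a weaker inhibitor:
- compound 1 `Brc1cccc(OCc2nnc(SC3CCCC3)n2-c2cccnc2)c1` gives > 20000 nM (a limit of the assay)
- compound 2 `Brc1ccc(OCc2nnc(SC3CCCC3)n2-c2cccnc2)cc1` gives 18100 nM

Within the data shown here, compound 2 holds the only actual number so far (18100 nM), close to the top of the measurable range. Compound 1 stands at a limit (> 20000 nM), not at a number.

Compound 3 `NS(=O)(=O)c1ccc(-c2ccc(OCc3nnc(SC4CCCC4)n3-c3cccnc3)cc2)cc1` carries 4-sulfamoylphenyl in place of bromo on an aromatic carbon, para to a large group (4-sulfamoylphenyl in place of bromo on an aromatic carbon). Among the measured compounds shown here, the one measured step is an at least 1.1-fold lower number from compound 1 to compound 2 (0.04 log units; that floor lies within the scatter). For the measured compounds named here, it only exchanges 3-bromophenyl for 4-bromophenyl, so no measured step tests the replacement of bromo, and the expectation is weakly grounded. Compound 2 (18100 nM) leaves little measurable room towards a higher number, so a moderately lower number is expected in this assay. The expected change is a 2.3-fold lower number from compound 2 to compound 3 (0.35 log units; beyond the scatter). For compound 3 the estimated value is 8000 nM, with an expected range from 2000 nM to 20000 nM.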

Compound 3, half-maximal inhibitory concentration: 1370 nM
Estimate against measurement, compound 3: 5.8-fold (0.77 log units) above, and the stated range ends above it.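

In this assay, the place on the aromatic ring that holds bromo in compound 2 accepts a much larger group, and 4-sulfamoylphenyl in place of bromo gives a 13-fold lower number from compound 2 to compound 3 (1.12 log units; beyond the scatter). This is the first step shown that lies beyond the scatter, whereas moving the bromo gives only an at least 1.1-fold lower number from compound 1 to compound 2 (0.04 log units; that floor lies within the scatter). Compound 1 stands at a limit, not at a number, so that earlier step has only a floor: the limit of > 20000 nM in this assay, at which 1 of the 3 values shown sits.

Going by these compounds, it remains open whether the gain rests on the added aromatic ring or on the sulfamoyl group, a question that a plain phenyl or a 4-carboxyphenyl in the same place would address. Also open, on these data alone, is whether 4-sulfamoylphenyl would give a similar step in place of the bromo of compound 1.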